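The compounds below may be only part of what the source reports. "The series", "measured", "known", "first", "only" and "open" are said of these compounds alone.

In a physicochemical assay for lipophilicity, read by LC-MS, using the shake flask method, in phosphate buffer, with a stated time of 50 min, at pH 7.4 (a lower number here means a more polar compound, a higher number a more lipophilic compound), compound 3 (`COCC(=O)OCCCCCC(=O)N[C@H](C(=O)N1C[C@H](O)C[C@H]1C(=O)NCc1ccc(-c2scnc2C)cc1)C(C)(C)C`) gives 1.7. This puts it in the middle of the three measured compounds. The highest number comes from compound 2 (`COCC(=O)NCCCCCC(=O)N[C@H](C(=O)N1C[C@H](O)C[C@H]1C(=O)NCc1ccc(-c2scnc2C)cc1)C(C)(C)C`) with 2.2, and the lowest from compound 1 (`CCCC(=O)OCCCCCC(=O)N[C@H](C(=O)N1C[C@H](O)C[C@H]1C(=O)NCc1ccc(-c2scnc2C)cc1)C(C)(C)C`) with 0.5.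

Compound 4 (`Cc1ncsc1-c1ccc(CNC(=O)[C@@H]2C[C@@H](O)CN2C(=O)[C@@H](NC(=O)CCCCCNC(=O)C2CCCCC2)C(C)(C)C)cc1`) has not yet been measured. It differs from compound 3 at one place: (cyclohexylcarbonyl)amino in place of ((methoxymethyl)carbonyl)oxy on a saturated chain carbon, five bonds along the chain from a carbonyl carbon. In words, (cyclohexylcarbonyl)amino stands in place of ((methoxymethyl)carbonyl)oxy on a saturated chain carbon, five bonds along the chain from a carbonyl carbon.

For the measured compounds named here, two measured steps bear on this change. The closer guide is a number 0.50 log units lower from compound 2 to compound 3 (beyond the scatter), where the oxy link replaces the amino link. Compound 4 makes the opposite exchange, so this modest step points upward. The second guide is a number 1.20 log units higher from compound 1 to compound 3 (beyond the scatter), a large step in which methoxy replaces ethyl at the far end of the group. It warns that a carbon-only end need not raise the number, since compound 1 lies lowest of the three. Going by the values given here, no measured compound carries a cyclohexyl group, so that part of the change remains untested.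

The expected change is a number 0.90 log units higher from compound 3 to compound 4 (beyond the scatter), an upward step with wide uncertainty. The estimated value for compound 4 is 2.6, within an expected range of 1.8 to 3.4.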

Compound 4, distribution coefficient: 1.4
Compound 4: the middle estimate sits 1.20 log units above what was measured, outside the stated range (below it).
By their numbers in this assay, from the lowest: compound 1; then compounds 4 and 3 (each within the scatter of the next); then compound 2.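

In this assay, putting (cyclohexylcarbonyl)amino in place of ((methoxymethyl)carbonyl)oxy on this saturated chain carbon gives a number 0.30 log units lower from compound 3 to compound 4 (within the scatter) and so does not separate the two compounds, while the same group in place of (propylcarbonyl)oxy gives a number 0.90 log units higher from compound 1 to compound 4 (beyond the scatter) as a clear difference. The more direct test of the ring is the step with the amino link held constant, where cyclohexyl in place of methoxymethyl on a carbonyl carbon gives a number 0.80 log units lower from compound 2 to compound 4 (beyond the scatter) and shows that the six-membered carbon ring, with more carbon atoms than the group it replaces, does not raise the number here. No measurement offered here explains these shifts.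

The compounds shown include no (cyclohexylcarbonyl)oxy group, so the oxy and amino links are directly compared only with methoxymethyl at the far end, and whether that link matters in the same way with cyclohexyl stays open. A phenyl ring, an open-chain hexyl group or an amine on the same carbonyl carbon would help show whether the step from compound 2 to compound 4 is specific to cyclohexyl.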